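The source may hold more compounds than are shown below. What is called first, only, known or untested is meant among the compounds shown, and "the series" means these compounds.

Working notes on the series.

Compound 1 `O=C(Nc1ccc([N+](=O)[O-])cc1)c1cc(Cl)ccc1O` and compound 2 `O=C(Nc1ccc([N+](=O)[O-])c(Cl)c1)c1cc(Cl)ccc1O` share one core; compound 3 `COc1cccc(NC(=O)c2cc(Cl)ccc2O)c1` and compound 4 `COc1ccc(Cl)c(NC(=O)c2cc(Cl)ccc2O)c1` share another. The difference between the two cores is not broken down here. In an ADME assay for permeability, using PAMPA (on this read-out lower numbers stand for lower permeability and higher numbers for higher permeability), compound 1 gives 127 10^-6 cm/s, compound 2 gives 68 10^-6 cm/s and compound 3 gives 43 10^-6 cm/s. Compound 3 stands lowest of the three, within the scatter of compound 2 and beyond it only against compound 1.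

Compound 2 differs from compound 1 by chloro in place of hydrogen on an aromatic carbon

which made a 1.9-fold lower number from compound 1 to compound 2 (0.27 log units; within the scatter).

Compound 4 differs from compound 3 by chloro in place of hydrogen on an aromatic carbon

This is the same kind of change, but the surroundings differ: in compound 2 the chloro enters ortho to a nitro group and meta to a large group, in compound 4 ortho to a large group and para to a methoxy group. The change occurs twice among the compounds shown, once measured.

Resting on the one measured step, a 1.9-fold lower number from compound 1 to compound 2 (0.27 log units; within the scatter), the expected step for compound 4 is a 1.5-fold lower number from compound 3 to compound 4 (0.19 log units; within the scatter) in this assay. Compound 4 is therefore estimated at 28 10^-6 cm/s, expected between 14 10^-6 cm/s and 56 10^-6 cm/s.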

Compound 4, apparent permeability in the ADME assay: 34 10^-6 cm/s
Compound 4: middle estimate off by 1.2-fold (0.08 log units), on the low side, within the range that was stated.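

In the ADME assay compound 3 gives 43 10^-6 cm/s and compound 4 gives 34 10^-6 cm/s, and the new step is a 1.3-fold lower number from compound 3 to compound 4 (0.10 log units; within the scatter), which agrees with the earlier one: the same change on two cores in the ADME assay, a 1.9-fold lower number (0.27 log units; within the scatter) from compound 1 to compound 2 and a 1.3-fold lower number (0.10 log units; within the scatter) from compound 3 to compound 4, 1.5-fold (0.17 log units) apart, within the scatter of two such steps. The chloro change therefore carries from the core of compound 1 to the core of compound 3 with no difference that can be told apart, but both steps lie within the scatter, so neither core shows a clear effect of the change on this read-out, and two cores make no general rule for the series. In a physicochemical assay for solubility (on this read-out lower numbers stand for lower solubility and higher numbers for higher solubility), compound 3 gives 2.3 ug/mL. In the physicochemical assay compound 4 gives < 1 ug/mL, which is a limit of the assay and not a number. Among the compounds shown here, in the physicochemical assay the only step, an at least 2.3-fold lower number from compound 3 to compound 4 (0.36 log units; beyond the scatter), rests on that limit and stands on one core only, so carrying the change across cores cannot be judged on that read-out.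

The compounds shown leave open whether the step would hold on a core bearing an amine or a carboxylic acid in place of the nitro or methoxy group. They also leave open whether fluoro or methyl in place of chloro would give a step beyond the scatter in the ADME assay.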